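The source may report more compounds than this note shows. Statements on the series, on what has been measured and on what is new or still open speak of the compounds shown alone.

Measured in an ADME assay on MDCK cells (Canis lupus familiaris) for cytotoxicity, read by MTT assay, with a stated time of 48 h; on this read-out higher numbers stand for lower toxicity in this test and lower numbers for higher toxicity in this test:
- Compound 1 `COC(=O)[C@H](CC(C)C)NC(=O)CSc1nc(-c2ccccc2)cc(-c2ccc(C)cc2)c1C#N`: 215000 nM
- Compound 2 `Cc1ccc(-c2cc(-c3ccccc3)nc(SCC(=O)N[C@H](C(=O)O)C(C)C)c2C#N)cc1`: > 250000 nM
- Compound 3 `Cc1ccc(-c2cc(-c3ccccc3)nc(SCNC(=O)OC(C)(C)C)c2C#N)cc1`: > 250000 nM

Compound 1 is the only one of the three with a number, 215000 nM. Compound 2 gives > 250000 nM, which is a limit of the assay. Compound 3 gives > 250000 nM, which is also a limit. The series is thus marked by the limit of > 250000 nM in this assay, at which 2 of the 3 values shown sit.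

Compound 4 `Cc1ccc(-c2cc(-c3ccccc3)nc(SCC(N)=O)c2C#N)cc1` is not yet measured. It differs from compound 1 by hydrogen in place of 1-(methoxycarbonyl)-3-methylbutyl on an amide-type nitrogen, which is hydrogen in place of 1-(methoxycarbonyl)-3-methylbutyl on an amide-type nitrogen.

Within the data shown here, two measured steps bear on this change. The closer one, an at least 1.1-fold higher number from compound 1 to compound 2 (0.06 log units; that floor lies within the scatter), alters the group on the same nitrogen, and its floor lies within the scatter. The other, a step that the two limits leave unreadable from compound 2 to compound 3, gives no readable size. The change in this assay is therefore expected to be small, an estimated 1.1-fold higher number from compound 1 to compound 4 (0.05 log units; within the scatter), with no step beyond the scatter in either direction. For compound 4 the expected value is 240000 nM, with an estimated range of 150000 nM to 380000 nM.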

Compound 4, half-maximal cytotoxic concentration: > 250000 nM
Compound 4 was reported as a limit (the forecaster's own chance of this, stated with the estimate: 55%); middle value at least 1.0-fold (0.01 log units) from the limit.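

In this assay, hydrogen in place of 1-(methoxycarbonyl)-3-methylbutyl on the amide-type nitrogen gives an at least 1.1-fold higher number from compound 1 to compound 4 (0.06 log units; that floor lies within the scatter) and so shows that this group can be taken off entirely, not only exchanged as in compound 2, without a step beyond the scatter. Compound 4 gives a limit and not a number, and the series now reads: the limit of > 250000 nM in this assay, at which 3 of the 4 values shown sit. The steps among compound 2, compound 3 and compound 4 cannot be read, as each joins two limits.

Going by these compounds, how far the true values of these three compounds lie from that limit stays open. Also open, on these data alone, is whether a methyl group or a longer chain on the amide-type nitrogen, or an amine on the saturated chain carbon bound to the sulfur, would give a number in this assay instead of a limit.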